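A few compounds are considered here, and "the series" means these few. Any claim that something is new, unique, unknown or untested is made for them only; others in the source may bear on it.

Compound 1 `O=C(O)CCCOc1ccc(-c2nc3ncccn3c2NC2CCCCC2)cc1` gives in a toxicity assay on A549 cells (Homo sapiens) for cytotoxicity, read by luminescence and CellTiter-Glo, with a stated time of 48 h (a higher number here means that more compound is tolerated, a lower number that less compound is tolerated), only a limit, > 100000 nM. Compound 2 `COCCOc1ccc(-c2nc3ncccn3c2NC2CCCCC2)cc1` likewise gives a limit in this assay, > 100000 nM. Compound 3 `Oc1ccc(-c2nc3ncccn3c2NC2CCCCC2)cc1` also gives a limit in this assay, > 100000 nM.

Compound 2 therefore stands where every measured compound stands: at the limit of > 100000 nM in this assay, at which 3 of the 3 values shown sit. The three steps among them, a step that the two limits leave unreadable from compound 1 to compound 2, a step that the two limits leave unreadable from compound 1 to compound 3 and a step that the two limits leave unreadable from compound 2 to compound 3, are all unreadable, and all concern the chain on the aromatic oxygen. Compound 4 `COCCOc1ccc(-c2nc3ncccn3c2Nc2ccccc2)cc1` differs from compound 2 elsewhere: phenyl in place of cyclohexyl on a nitrogen on an aromatic ring. Among the measured compounds shown here, no measured step touches that nitrogen, so nothing readable bears on it. With every value at the limit, the step from compound 2 to compound 4 is expected to stay within the scatter, a number no higher from compound 2 to compound 4 (the limit leaves the size open). Compound 4 is expected to give about 100000 nM in this assay, within 30000 nM to 300000 nM, most likely again only as a limit.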

Compound 4, half-maximal cytotoxic concentration: > 100000 nM
Compound 4 gave a limit, no number; the forecaster's own chance of this, stated with the estimate: 75%; the middle value lies on the limit itself.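

In this assay compound 4 gives > 100000 nM as a limit only. Compound 2 also gives only a limit, so no new step can be read between compound 2 and compound 4. The compounds shown leave open what concentration any of them would take to reach half-maximal cytotoxicity.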